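This account rests on a few compounds, and the source may have more. Where it says the series, first, only, none or still open, it means among the compounds named here.

Measured so far:
- compound 1 `O=C(Cn1c(=O)oc2cc(Cl)ccc21)NCc1cccs1`: 53.6%
- compound 2 `O=C(Cn1c(=O)oc2cc(Cl)ccc21)NCc1ccco1`: 50.3%

In an ADME assay on RAW264.7 cells (Mus musculus) for cytotoxicity, read by MTT assay, with a stated time of 72 h, tested at 100 uM (on this read-out lower numbers stand for a weaker effect and higher numbers for a stronger effect at the one concentration tested), compound 2 gives 50.3% and stands together with compound 1, which gives 53.6%; the step of a number 3.3 percentage points lower from compound 1 to compound 2 (within the scatter) lies within the scatter. Compound 3 `O=C(Cn1c(=O)oc2cc(Cl)ccc21)Nc1ccccn1` differs from compound 2 by pyridin-2-yl in place of (furan-2-yl)methyl on an amide-type nitrogen. For the measured compounds named here, the only measured step, a number 3.3 percentage points lower from compound 1 to compound 2 (within the scatter), exchanged one five-membered ring for another on a saturated chain carbon; no step exchanges a ring bound through a saturated chain carbon for a ring bound directly to the amide-type nitrogen, so that step bears only loosely. No step beyond the scatter is expected: a number 0.3 percentage points lower from compound 2 to compound 3 (within the scatter). Compound 3 is therefore estimated at 50%, in the range 35% to 65%.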

Compound 3, a percentage reported as inhibition, at one concentration (the size of the read-out at that concentration, not a potency): 43.7%
Beside the measured number, compound 3's estimate is 6.3 percentage points above it; low and high end bracket the measured number.
By their numbers in this assay, from the lowest: compounds 3, 2 and 1 (each within the scatter of the next).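

In this assay the amide-type nitrogen now carries a six-membered aromatic ring directly, without the saturated chain carbon, and the read-out stays within the scatter: a number 6.6 percentage points lower from compound 2 to compound 3 (within the scatter) and a number 9.9 percentage points lower from compound 1 to compound 3 (within the scatter). This position therefore accepts pyridin-2-yl in place of either (hetero)arylmethyl group with no step beyond the scatter. Nothing available explains this result.

The change alters ring size and removes the chain carbon at once, so the two remain unseparated. On these data alone, a longer chain, an amine or a carboxylic acid on this nitrogen remains open.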